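Ring attachment change on the core of compound 1

The compounds below may be only part of what the source reports. "The series", "measured", "known", "first", "only" and "open" are said of these compounds alone.

Measured so far:
compound 1, `Nc1ncnc2c1c(-c1ccc(Oc3ccccc3)cc1)cn2[C@H]1CCN(C[C@H]2CO2)C1`: 15700 nM
compound 2, `Nc1ncnc2c1c(-c1cnc3[nH]ccc3c1)cn2[C@H]1CCN(C[C@@H]2CO2)C1`: 2990 nM

In a functional assay on Daudi cells (Homo sapiens) for antiproliferative activity (a lower number here means a stronger inhibitor, a higher number a weaker inhibitor), compound 1 gives 15700 nM, the highest of the two numbers measured. Compound 2 gives 2990 nM, a lower number, and the gap between the two lies beyond the scatter. The two compounds differ in the aromatic group on the core, so nothing measured yet speaks to the part that changes next.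

Compound 3, `Nc1ncnc2c1c(-c1ccc(Oc3ccccc3)cc1)cn2C[C@H]1CCCN1C[C@@H]1CO1`, is not yet measured. It differs from compound 1 in one place: (1-((oxiran-2-yl)methyl)pyrrolidin-2-yl)methyl in place of 1-((oxiran-2-yl)methyl)pyrrolidin-3-yl on an aromatic nitrogen. The pyrrolidine ring, with its oxirane-bearing chain, is now joined to the aromatic nitrogen through a methylene and at a different ring position. Within the data shown here, no pair of measured compounds shows what such a change does here, so the expectation rests on compound 1 alone.

The step of a 1.1-fold higher number from compound 1 to compound 3 (0.06 log units; within the scatter) is expected to be small, with no clear direction, and may well stay within the scatter. Compound 3 is therefore estimated at 18000 nM in this assay, within a wide range from 5000 nM to 70000 nM.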

Compound 3, half-maximal inhibitory concentration: 7040 nM
The estimate for compound 3 lay 2.6-fold (0.41 log units) above the measured number; the range from low to high includes it.
By their numbers in this assay, from the lowest: compound 2; then compound 3; then compound 1.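

In this assay, (1-((oxiran-2-yl)methyl)pyrrolidin-2-yl)methyl in place of 1-((oxiran-2-yl)methyl)pyrrolidin-3-yl on the aromatic nitrogen gives a 2.2-fold lower number from compound 1 to compound 3 (0.35 log units; beyond the scatter), so the series now has a single-place step showing that this position responds to a change in how the pyrrolidine is attached. The two groups carry the same ring types and the same hydrogen-bond donor and acceptor counts, but the step combines the added methylene with the move from the pyrrolidin-3-yl to the pyrrolidin-2-yl attachment, and these two changes cannot be separated here. No measured evidence accounts for the lower number.

On these data alone, it remains open whether the methylene or the attachment point drives the step, and whether the same change would give a similar step with the aromatic group of compound 2 on the shared core. Also open, as far as these compounds go, is how a piperidine ring in place of the pyrrolidine, or an acrylamide in place of the oxirane-bearing chain, would behave at this position.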